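Methoxy in place of nitro on the benzoate of compound 1

The source may hold more compounds than are shown below. What is called first, only, known or untested is meant among the compounds shown, and "the series" means these compounds.

Compound 1 `CC1=CC[C@H](C(C)C)c2cc(C)c(OC(=O)c3ccc([N+](=O)[O-])cc3)cc21` gives 67.8% in a functional assay on HCT-15 cells (Homo sapiens) for antiproliferative activity, read by sulforhodamine B assay, with a stated time of 48 h, tested at 50 uM (on this read-out higher numbers stand for more inhibition at the one concentration tested (going by the name of the read-out) and lower numbers for less inhibition), the highest of the three numbers recorded. Compound 2 `Cc1cc2c(C(C)C)ccc(C)c2cc1OC(=O)c1ccc(C(F)(F)F)cc1` gives 55.6% in this assay, a number lower than that of compound 1 by more than the usual scatter. Compound 3 `COc1cccc(C(=O)Oc2cc3c(C)ccc(C(C)C)c3cc2C)c1` gives 35.2% in this assay, the lowest of the three and furthest from compound 1. Among the compounds with values here, compounds 2 and 3 differ from compound 1 in more than one place, so no single step connects them to it; only their values can be set side by side.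

Compound 4 `COc1ccc(C(=O)Oc2cc3c(cc2C)[C@@H](C(C)C)CC=C3C)cc1` has not yet been measured. It differs from compound 1 in one place: methoxy in place of nitro on an aromatic carbon. Within the data shown here, no measured pair shows this change alone. Among the measured compounds shown here, as compound 3, the one compound that carries a methoxy on the benzoate, gives the lowest value 35.2%, the step is expected to run downward and to exceed the scatter. For compound 4 the estimate in this assay is 45%, within a range from 25% to 65%, so that the step from compound 1 to compound 4 is expected to be a number 22.8 percentage points lower from compound 1 to compound 4 (beyond the scatter).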

Compound 4, a percentage reported as inhibition, at one concentration (the size of the read-out at that concentration, not a potency): 30.8%
For compound 4 the middle estimate is 14.2 percentage points above the measured one; the measured number falls inside the stated range.
By their numbers in this assay, from the lowest: compounds 4 and 3 (each within the scatter of the next); then compound 2; then compound 1.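

Within the data shown here, replacing nitro with methoxy on an aromatic carbon, para to a large group, gives in this assay a number 37 percentage points lower from compound 1 to compound 4 (beyond the scatter) and provides the first direct reading of this position. The earlier compounds shown here could not isolate this change, since they differ from compound 1 in more than one place, but here the core of compound 1 stays the same and the 4-nitrophenyl becomes a 4-methoxyphenyl. The change at this single position is therefore enough to shift the inhibition at the one concentration tested, though nothing available explains the direction or size of that shift.

One pair cannot show how other groups at this position would read, such as an amine, a carboxylic acid or a chlorine atom. It also leaves open whether the same exchange would produce a similar step on the core of compound 2.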